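Phenylurea to naphthylurea: cytotoxicity expectation for compound 3

The compounds below may be only part of what the source reports. "The series", "measured", "known", "first", "only" and "open" are said of these compounds alone.

Measured compounds:
- compound 1 `CN(c1cc2ncc(=O)[nH]c2cc1NC(=S)NC(=O)c1ccco1)C1CCCCC1`: 17300 nM
- compound 2 `CN(c1cc2ncc(=O)[nH]c2cc1NC(=O)Nc1ccccc1)C1CCCCC1`: 5520 nM

In an ADME assay on Huh-7 cells (Homo sapiens) for cytotoxicity (a higher number here means a weaker inhibitor, a lower number a stronger inhibitor), compound 1 gives 17300 nM, and compound 2 gives 5520 nM. Among the compounds with values here, of the two numbers, compound 2 holds the lower one, so it is the stronger inhibitor of cell growth here; the only step measured, a 3.1-fold lower number from compound 1 to compound 2 (0.50 log units; beyond the scatter), exchanged the whole furan-carrying thiourea arm for the phenylurea arm.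

Compound 3 `CN(c1cc2ncc(=O)[nH]c2cc1NC(=O)Nc1cccc2ccccc12)C1CCCCC1` differs from compound 2 in one place: naphthalen-1-yl in place of phenyl on an amide-type nitrogen. Within the data shown here, no measured step touches this change directly. The step from compound 1 to compound 2 concerns a different part of the molecule, so it offers only a general hint that the group at this position matters for the read-out in this assay, without saying in which direction a larger aromatic group would move it. A second ring of carbon atoms adds bulk without changing donors or acceptors; the expectation is a modest shift toward a lower number, a 1.6-fold lower number from compound 2 to compound 3 (0.20 log units; within the scatter), with wide uncertainty. Compound 3 is therefore estimated at 3500 nM, within a range from 1200 nM to 12000 nM.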

Compound 3, half-maximal inhibitory concentration: 5330 nM
Compound 3: middle estimate off by 1.5-fold (0.18 log units), on the low side; the measured number falls inside the stated range.
By their numbers in this assay, from the lowest: compounds 3 and 2 (each within the scatter of the next); then compound 1.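

The swap of phenyl for naphthalen-1-yl on the amide-type nitrogen, read in this assay, gives a 1.0-fold lower number from compound 2 to compound 3 (0.02 log units; within the scatter) and so leaves the two numbers indistinguishable. The earlier step replaced the whole arm at once, whereas this pair alters only the aromatic group on this nitrogen and shows that adding a second ring of carbon atoms, going from 6 to 10 heavy atoms, has no readable effect on this number in this one case. No independent measurement bears on why these two compounds read alike.

On these data alone, one enlargement of an all-carbon aromatic group cannot show how this position behaves in general, and it remains open whether naphthalen-2-yl, a pyridine ring or a small methyl group on the same nitrogen would read the same way. Also open, as far as these compounds go, is whether a phenyl ring carrying a carboxylic acid or an amine would shift the number, since every group at this position in the urea pair consists of carbon-only aromatic rings.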